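This account rests on a few compounds, and the source may have more. Where it says the series, first, only, none or still open, it means among the compounds named here.

Measured in a functional assay on A549 cells (Homo sapiens) for antiproliferative activity, read by MTT assay, with a stated time of 24 h; a higher number here means a weaker inhibitor, a lower number a stronger inhibitor:
Compound 1 `C=CCc1cc(-c2cccc(C(F)(F)F)c2)ccc1O`: 73000 nM
Compound 2 `C=CCc1cc(-c2ccccc2)ccc1O`: > 100000 nM

In this assay compound 2 stands only at a limit, > 100000 nM, and not at a number. Compound 3 `C=CCc1cc(-c2cccc(SC)c2)ccc1O` differs from compound 2 by one change: methylsulfanyl in place of hydrogen on an aromatic carbon. Among the compounds with values here, the one measured step bearing on this is an at least 1.3-fold higher number from compound 1 to compound 2 (0.13 log units; that floor lies within the scatter), where hydrogen replaces trifluoromethyl, and its floor lies within the scatter. Going by that step, a modest move towards a lower number is expected, perhaps none beyond the scatter. The estimated step is an at least 1.3-fold lower number from compound 2 to compound 3 (0.12 log units; that floor lies within the scatter). For compound 3 the estimate is 75000 nM, with an expected range of 35000 nM to 150000 nM.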

Compound 3, half-maximal inhibitory concentration: 66000 nM
Estimate against measurement, compound 3: 1.1-fold (0.06 log units) above; measured number inside the range.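

In this assay, from the compounds shown here alone, putting methylsulfanyl on this aromatic carbon in place of hydrogen gives an at least 1.5-fold lower number from compound 2 to compound 3 (0.18 log units; that floor lies within the scatter), so this change has only a floor and its true size stays unknown. Compound 2 stands at a limit and not at a number: the limit of > 100000 nM in this assay, at which 1 of the 3 values shown sits. Exchanging trifluoromethyl for methylsulfanyl at the same place gives a 1.1-fold lower number from compound 1 to compound 3 (0.04 log units; within the scatter), so the two groups cannot be told apart here.

The compounds shown leave open whether an amine, a carboxylic acid or a longer chain at this place would move the number beyond the scatter.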